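A few compounds are considered here, and "the series" means these few. Any claim that something is new, unique, unknown or untested is made for them only; others in the source may bear on it.

Measured compounds: compound 1 `CC(=O)OC(C)n1cnc2c(Cl)nc(N)nc21` gives > 500000 nM; compound 2 `CC(O)n1cnc2c(Cl)nc(I)nc21` gives 479000 nM.

In a functional assay on FM3A cells (Homo sapiens) for inhibition, with FM3A (Mus musculus) as the target (on this read-out higher numbers stand for weaker inhibition and lower numbers for stronger inhibition), compound 1 gives only a limit of the assay, > 500000 nM, and not a number, which is the situation described by the limit of > 500000 nM in this assay, at which 1 of the 2 values shown sits. Compound 2 shows a number in this assay, 479000 nM, yet compound 1 and compound 2 share no single change between them, so their values stand alone. Among the measured compounds shown here, compound 3 `CC(=O)OC(C)n1cnc2c(Cl)nc(F)nc21` differs from compound 1 by fluoro in place of amino on an aromatic carbon; no measured pair tells how large a step this brings. The step of a number no higher from compound 1 to compound 3 (the limit leaves the size open) is expected to stay within the scatter. Compound 3 is therefore estimated at 500000 nM in this assay, with a range from 150000 nM to 2000000 nM.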

Compound 3, half-maximal inhibitory concentration: 93000 nM
Compound 3: the middle estimate sits 5.4-fold (0.73 log units) above what was measured, and the stated range ends above it.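

In this assay, fluoro in place of amino on an aromatic carbon between two ring nitrogen atoms brings an at least 5.3-fold lower number from compound 1 to compound 3 (0.73 log units; beyond the scatter). Among the compounds shown here, this is the first single change that can be read here, and it shows that the number responds to what sits on this carbon. The full size of the step stays unknown because compound 1 gives only a limit: the limit of > 500000 nM in this assay, at which 1 of the 3 values shown sits.

Going by these compounds, whether a methoxy group or a methyl group on this carbon would give a lower or higher number remains open. This one pair also cannot tell whether the same change would act alike on the core of compound 2.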